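Working notes: from compound 3 to compound 4

A few compounds are considered here, and "the series" means these few. Any claim that something is new, unique, unknown or untested is made for them only; others in the source may bear on it.

Measured compounds in a functional assay on RAW264.7 cells (Mus musculus) for inhibition, read by immunoassay, with a stated time of 12 h, tested at 30 uM; on this read-out higher numbers stand for more inhibition at the one concentration tested (going by the name of the read-out) and lower numbers for less inhibition:
Compound 1 `O=C1CC(c2ccccc2OCc2cccc(F)c2)Oc2ccccc21` gives 93.3%.
Compound 2 `CC(C)c1ccc(COc2ccccc2C2CC(=O)c3ccccc3O2)cc1` gives 91.5%.
Compound 3 `O=C1CC(c2ccccc2OCc2ccc(F)cc2)Oc2ccccc21` gives 45.2%.

Compound 3 stands lowest of the three numbers in this assay. Its nearest neighbour is compound 2, reached by the step of a number 46.3 percentage points lower from compound 2 to compound 3 (beyond the scatter), and the furthest is compound 1, reached by the step of a number 48.1 percentage points lower from compound 1 to compound 3 (beyond the scatter). Compound 1 and compound 2 lie close together, the step being a number 1.8 percentage points lower from compound 1 to compound 2 (within the scatter).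

Compound 4 `CCCCOc1ccccc1C1CC(=O)c2ccccc2O1` has not yet been measured. It differs from compound 3 as follows: propyl in place of 4-fluorophenyl on a saturated chain carbon bound to an oxygen on an aromatic ring.

Both large steps, a number 48.1 percentage points lower from compound 1 to compound 3 (beyond the scatter) and a number 46.3 percentage points lower from compound 2 to compound 3 (beyond the scatter), change only what sits on the six-membered aromatic ring that now leaves, and both end at compound 3. Among the measured compounds shown here, no measured step removes that ring or puts a chain in its place, so the change to compound 4 is covered only loosely. The two large steps show that this part of the molecule moves the read-out strongly, so a step beyond the scatter is expected in this assay, with the direction uncertain and a fall from compound 3 somewhat more likely than a rise, since compound 3 is already the lowest measured.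

For compound 4 the expected value in this assay is 35%, within 5% to 75%, which corresponds to an expected step of a number 10.2 percentage points lower from compound 3 to compound 4 (beyond the scatter).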

Compound 4, a percentage reported as inhibition, at one concentration (the size of the read-out at that concentration, not a potency): 19.3%
The estimate for compound 4 lay 15.7 percentage points above the measured number; measured number inside the range.
By their numbers in this assay, from the lowest: compound 4; then compound 3; then compounds 2 and 1 (each within the scatter of the next).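

In this assay, among the compounds shown here, compound 4 is the first compound with no aromatic ring on the saturated chain carbon bound to an oxygen on an aromatic ring, and swapping 4-fluorophenyl for propyl there gives a number 25.9 percentage points lower from compound 3 to compound 4 (beyond the scatter), leaving compound 4 the lowest of the four. The same swap measured against the two high compounds gives a number 72.2 percentage points lower from compound 2 to compound 4 (beyond the scatter) and a number 74 percentage points lower from compound 1 to compound 4 (beyond the scatter), so all three compounds with an aromatic ring at this place stand above the propyl compound, although compound 3 shows that the ring alone does not secure a high number. No measurement on hand explains why the read-out falls with this change.

Open, going by these compounds, is whether the fall follows from losing the ring or from the shorter reach of the group, which a cyclohexyl group, a longer chain or an unsubstituted phenyl at this place would help to separate. Also open, on these data alone, is whether a chain ending in an amine or a carboxylic acid would stay as low as compound 4, and how these single-concentration numbers relate to potency.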